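A few compounds are considered here, and "the series" means these few. Any claim that something is new, unique, unknown or untested is made for them only; others in the source may bear on it.

Measured so far in an assay on isolated protein for binding affinity to Alpha-1D adrenergic receptor (Homo sapiens), read by radioligand binding; a lower number here means a stronger inhibitor, a higher number a weaker inhibitor:

compound 1 `COc1ccccc1N1CCN(CCNc2c(C(=O)C(C)C)c(-c3ccccc3)nn(C)c2=O)CC1`: 0.43 nM
compound 2 `COc1ccccc1N1CCN(CCCNc2c(C(C)=O)c(-c3ccccc3)nn(C)c2=O)CC1`: 4.32 nM
compound 3 `CC(=O)c1c(-c2ccccc2)nn(C)c(=O)c1NCCN1CCN(c2ccccc2F)CC1`: 0.49 nM

Compound 3 gives the second highest of the three numbers in this assay. Its nearest neighbour is compound 1, whose number sits only slightly lower, well within the scatter of this kind of measurement, so the two cannot be told apart. For the measured compounds named here, compound 2 is the furthest from compound 3, with a number clearly higher and beyond the scatter; no single-point step links these two, so only the two values themselves are noted here.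

Compound 4 `CC(=O)c1c(-c2ccccc2)nn(C)c(=O)c1NCCN1CCN(c2ccccc2Cl)CC1` is the next entry to be measured in this assay. It differs from compound 3 in one place: chloro in place of fluoro on an aromatic carbon. Going by the values given here, no pair of measured compounds shows a change of this kind, so there is no step to lean on.

The expectation is a step from compound 3 to compound 4 of a 1.4-fold higher number from compound 3 to compound 4 (0.15 log units; within the scatter), small and not beyond the scatter. Compound 4 is therefore estimated at 0.7 nM, with a range from 0.25 nM to 2 nM.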

Compound 4, inhibition constant: 0.25 nM
For compound 4 the middle estimate is 2.8-fold (0.45 log units) above the measured one; the measured number falls inside the stated range.
By their numbers in this assay, from the lowest: compounds 4, 1 and 3 (each within the scatter of the next); then compound 2.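

In this assay, the change from 2-fluorophenyl to 2-chlorophenyl gives the only single-place step in the compounds shown, a 2.0-fold lower number from compound 3 to compound 4 (0.29 log units; within the scatter), so this aromatic carbon, ortho to a large group, accepts chloro as well as fluoro. With the step inside the scatter, compound 3 and compound 4 count as one level in this assay, and no order can be drawn between these two halogens. No measurement at hand bears on the reason for this result.

Left open is whether the same aromatic carbon also accepts a group other than a halogen, such as trifluoromethyl, an amine or a carboxylic acid, and how bromo or plain hydrogen would read there. Also open, on these data alone, is whether chloro in place of fluoro gives a similar step when the rest of the molecule carries a longer chain.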